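Trading trifluoromethoxy for methoxy in a growth inhibition series

A few compounds are considered here, and "the series" means these few. Any claim that something is new, unique, unknown or untested is made for them only; others in the source may bear on it.

In a functional assay on NCI-H460 cells (Homo sapiens) for inhibition, read by MTT assay, with a stated time of 24 h, tested at 0.1 ug/mL (on this read-out lower numbers stand for less inhibition of growth and higher numbers for more inhibition of growth at the one concentration tested), compound 1 (`O=C(CCCCC(S)CCS)Nc1ccccc1`) gives 5.5%, while compound 2 (`O=C(CCCCC(S)CCS)Nc1ccc(OC(F)(F)F)cc1`) gives 17.3%. Within the data shown here, compound 2 therefore holds the higher of the two numbers so far, and the gap between them lies beyond the scatter. Compound 3 (`COc1ccc(NC(=O)CCCCC(S)CCS)cc1`) has not yet been measured in this assay. It differs from compound 2 in one place: methyl in place of trifluoromethyl on an oxygen on an aromatic ring. Put simply, trifluoromethoxy becomes methoxy.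

Among the measured compounds shown here, only one measured step bears on this change: a number 11.8 percentage points higher from compound 1 to compound 2 (beyond the scatter), a modest rise that came with trifluoromethoxy in place of hydrogen on an aromatic carbon. For the measured compounds named here, no measured compound carries methoxy alongside these two, so this step offers only a rough guide to size and direction. Part of that rise is expected to be lost, leaving compound 3 between the two measured compounds. The estimated step is a number 6.3 percentage points lower from compound 2 to compound 3 (within the scatter), a small fall expected to stay within the scatter. Compound 3 is expected to give 11%, with an estimated range of 3% to 23%.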

Compound 3, percent growth inhibition at one concentration: 5.69%
Compound 3: the middle estimate sits 5.3 percentage points above what was measured, within the range that was stated.
By their numbers in this assay, from the lowest: compounds 1 and 3 (each within the scatter of the next); then compound 2.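

In this assay, trading trifluoromethoxy for methoxy brings a number 11.6 percentage points lower from compound 2 to compound 3 (beyond the scatter), so the gain seen with trifluoromethoxy does not carry over to every oxygen-linked group at this place on the aromatic ring. Methoxy in place of hydrogen on the aromatic carbon gives a number 0.2 percentage points higher from compound 1 to compound 3 (within the scatter), which means that the oxygen with a methyl on it leaves no measurable mark here, and among these three compounds only the one with trifluoromethyl on the oxygen stands apart. Nothing at hand offers a reason for this difference between trifluoromethyl and methyl on the oxygen.

The compounds shown leave open whether the oxygen is needed at all, since a trifluoromethyl group set directly on the aromatic carbon would separate its part from that of the fluorines, and whether a difluoromethoxy or an ethoxy group would fall with compound 2 or with compound 1. They also leave open whether the same order would hold at other concentrations, as every number here comes from a single tested concentration.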